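The source may hold more compounds than are shown below. What is called first, only, known or untested is meant among the compounds shown, and "the series" means these compounds.

Two amides on a shared core, compound 1 `COc1ccc(-c2cnc(NC(=O)c3cccc(C)c3)n2C)cc1` and compound 2 `COc1ccc(-c2cnc(NC(=O)c3cccc(F)c3)n2C)cc1`, have been measured in a toxicity assay on THP-1 cells (Homo sapiens) for inhibition; a lower number here means that less compound is tolerated, a higher number that more compound is tolerated. Compound 1 gives > 100000 nM, which is a limit of the assay and not a number. Compound 2 gives > 100000 nM, which is likewise a limit. Compound 2 thus stands only at the limit of > 100000 nM in this assay, at which 2 of the 2 values shown sit, with no number to place it more exactly. Among the compounds with values here, the single measured step, a step that the two limits leave unreadable from compound 1 to compound 2, is fluoro in place of methyl on an aromatic carbon, and it gives no size to carry forward.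

Compound 3 `COc1ccc(-c2cnc(NC(=O)c3ccccc3Br)n2C)cc1` brings a different change, with 2-bromophenyl in place of 3-fluorophenyl on a carbonyl carbon. The step from compound 1 to compound 2 bears on this only loosely, and no readable step supports a direction in this assay. The expectation therefore rests on compound 2 at > 100000 nM, a limit, and no clear shift is foreseen. The expected step is an at least 1.1-fold lower number from compound 2 to compound 3 (0.04 log units; that floor lies within the scatter). For compound 3 the estimated value is 90000 nM, with an expected range from 35000 nM to 150000 nM.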

Compound 3, half-maximal cytotoxic concentration: > 100000 nM
Compound 3: only a limit was reported (the forecaster's own chance of this, stated with the estimate: 80%); middle value at least 1.1-fold (0.04 log units) away from the limit.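

In this assay compound 3 gives > 100000 nM, which is a limit of the assay and not a number, so its steps from compound 1 and compound 2 cannot be read. All three compounds stand at the same mark: the limit of > 100000 nM in this assay, at which 3 of the 3 values shown sit.

The compounds shown leave open whether any group on the carbonyl carbon would give a measurable number in this assay.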